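Thiosemicarbazone series: fluoro to nitro on the aryl ring

A few compounds are considered here, and "the series" means these few. Any claim that something is new, unique, unknown or untested is made for them only; others in the source may bear on it.

Measured so far, in a functional assay on U-87MG ATCC cells (Homo sapiens) for cytotoxicity, read by MTT assay, with a stated time of 48 h; a lower number here means a stronger inhibitor, a higher number a weaker inhibitor:
- compound 1 `CC(=NNC(=S)Nc1ccccc1F)c1ccccn1`: 5 nM
- compound 2 `CC(=NNC(=S)Nc1ccccc1[N+](=O)[O-])c1ccccn1`: 4.3 nM
- compound 3 `CC(=NNC(=S)Nc1ccc(F)cc1)c1ccccn1`: 10 nM

Compound 1 and compound 2 share the same core; the change between them is nitro in place of fluoro on an aromatic carbon. That step is a 1.2-fold lower number from compound 1 to compound 2 (0.07 log units; within the scatter), so the two compounds sit within the usual scatter of each other and no order can be read from them.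

Compound 3 has the same atoms as compound 1 joined differently; the difference between the two cores is not broken down here. Compound 3 gives the highest number of the three, but its gap to compound 1 is within the scatter, while its gap to compound 2 is beyond it, so compound 3 does give a higher number than compound 2.

Compound 4 `CC(=NNC(=S)Nc1ccc([N+](=O)[O-])cc1)c1ccccn1` is not yet measured. It differs from compound 3 by nitro in place of fluoro on an aromatic carbon. For the measured compounds named here, this is the same kind of change as the one from compound 1 to compound 2, but the place is not the same: there the nitro sits ortho to a large group, here para to a large group. Going by the values given here, the only measured instance of this change is the step from compound 1 to compound 2, which was within the scatter. Resting on that step, a 1.2-fold lower number from compound 1 to compound 2 (0.07 log units; within the scatter), compound 4 is expected to stay close to compound 3, with an estimated step of a 1.3-fold lower number from compound 3 to compound 4 (0.10 log units; within the scatter). The estimate for compound 4 in this assay is 8 nM, expected to fall between 4 nM and 18 nM.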

Compound 4, half-maximal inhibitory concentration: 160 nM
Estimate against measurement, compound 4: 20-fold (1.30 log units) below, and the stated range ends below it.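

In this assay, nitro in place of fluoro, para to a large group, gives a 16-fold higher number from compound 3 to compound 4 (1.20 log units; beyond the scatter), so the result of this change on one core cannot be taken as a guide to its result on the other in this series. Set beside the earlier instance, the two steps differ: the same change on two cores in this assay, a 1.2-fold lower number (0.07 log units; within the scatter) from compound 1 to compound 2 and a 16-fold higher number (1.20 log units; beyond the scatter) from compound 3 to compound 4, 19-fold (1.27 log units) apart, beyond the scatter of two such steps

This shows that the same change need not give the same step across these two cores, but it does not show why, since the two cores differ in where the group sits and each instance rests on a single pair of compounds, so no rule for carrying the change to a further core can be drawn from them.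

On these data alone, it remains open whether the large step belongs to nitro itself or would also appear with other groups in place of fluoro at the same place, such as a chlorine atom, a methoxy group, an amine or a carboxylic acid. As far as these compounds go, it also remains open whether the small step seen between compound 1 and compound 2 would hold for those same groups on the core of compound 1, which would show whether the gap between the two cores is specific to nitro.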